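Ester chain length on the aryloxy side of a shared core

The compounds below may be only part of what the source reports. "The series", "measured", "known", "first", "only" and "open" are said of these compounds alone.

Compound 1 `CCOC(=O)CCCOc1ccc(-n2cnc(-c3ccccc3)c2-c2ccccc2)cc1` — 64 nM
Compound 2 `COC(=O)COc1cccc(-n2cnc(-c3ccccc3)c2-c2ccccc2)c1` — 6500 nM

In an assay on H4 cells for inhibition of Fatty-acid amide hydrolase 1 (Homo sapiens) (on this read-out higher numbers stand for weaker inhibition and lower numbers for stronger inhibition), compound 2 gives 6500 nM, the highest of the two numbers recorded; the nearest, compound 1, gives 64 nM, which stands far beyond the scatter. Compound 3 `CCOC(=O)CCCOc1cccc(-n2cnc(-c3ccccc3)c2-c2ccccc2)c1` carries 2-(ethoxycarbonyl)ethyl in place of methoxycarbonyl on a saturated chain carbon bound to an oxygen on an aromatic ring, so it bears the 3-(ethoxycarbonyl)propoxy group also present in compound 1. Going by the values given here, no measured pair isolates this change, so the step from compound 2 to compound 3 is estimated, expected to run toward stronger inhibition and to exceed the scatter, as an 11-fold lower number from compound 2 to compound 3 (1.03 log units; beyond the scatter). Compound 3 is thus expected at about 600 nM, within 120 nM to 3000 nM.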

Compound 3, half-maximal inhibitory concentration: 91 nM
Beside the measured number, compound 3's estimate is 6.6-fold (0.82 log units) above it; the measured number lies below the stated range.
By their numbers in this assay, from the lowest: compounds 1 and 3 (each within the scatter of the next); then compound 2.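

In this assay, 2-(ethoxycarbonyl)ethyl in place of methoxycarbonyl on a saturated chain carbon bound to an oxygen on an aromatic ring gives a 71-fold lower number from compound 2 to compound 3 (1.85 log units; beyond the scatter), so this position responds strongly to this change. The two compounds bearing the 3-(ethoxycarbonyl)propoxy group, compound 1 and compound 3, stand within the scatter of each other. No evidence here accounts for the size of the step.

The change alters chain length and ester together, and the compounds shown do not separate the two. Also open, going by these compounds, is how a carboxylic acid or an amide at the chain end, or a longer chain, would read.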